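Compound 1 to compound 4: sulfanyl to sulfonyl

The source may hold more compounds than are shown below. What is called first, only, known or untested is meant among the compounds shown, and "the series" means these compounds.

Measured in a functional assay on DU-145 cells (Homo sapiens) for inhibition, read by trypan blue exclusion, with a stated time of 96 h; a lower number here means a stronger inhibitor of growth, a higher number a weaker inhibitor of growth:
- compound 1 `CCOc1ccc(/C=C(/SCc2ccc(C)cc2)C(=O)c2ccc(Cl)cc2)cc1OC` gives 25000 nM
- compound 2 `COc1cc(OC)c(/C=C(/SCc2ccc(Cl)cc2Cl)C(=O)c2ccc(Cl)cc2)c(OC)c1` gives 1000 nM
- compound 3 `Cc1ccc(/C=C(/SCc2ccc(F)cc2)C(=O)c2ccc(Cl)cc2)s1` gives > 100000 nM

The entry for compound 3 is a limit of the assay and not a number. Of the two numeric values, compound 1 has the higher, so it is the weaker growth inhibitor of the pair, and compound 2 lies lower by more than the scatter.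

Compound 4 `CCOc1ccc(/C=C(\C(=O)c2ccc(Cl)cc2)S(=O)(=O)c2ccc(C)cc2)cc1OC` has not yet been measured. It differs from compound 1 in one place ((4-methylphenyl)sulfonyl in place of (4-methylbenzyl)sulfanyl on a double-bonded chain carbon bound to a carbonyl carbon and a double-bonded chain carbon), with (4-methylphenyl)sulfonyl in place of (4-methylbenzyl)sulfanyl on a double-bonded chain carbon bound to a carbonyl carbon and a double-bonded chain carbon.

For the measured compounds named here, no measured pair isolates this change. The expectation in this assay therefore rests on compound 1 at 25000 nM (no step beyond the scatter is expected, in either direction). The estimated step is a 1.3-fold lower number from compound 1 to compound 4 (0.10 log units; within the scatter) (expected, with wide uncertainty). Compound 4 is expected at 20000 nM (estimated range 4000 nM to 100000 nM).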

Compound 4, concentration for 50% growth inhibition: 1000 nM
Compound 4: the middle estimate sits 20-fold (1.30 log units) above what was measured, and the stated range ends above it.
By their numbers in this assay, from the lowest: compounds 2 and 4 (each within the scatter of the next); then compound 1. At a limit, above all of these: compound 3.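

For the compounds shown here, the change gives a 25-fold lower number from compound 1 to compound 4 (1.40 log units; beyond the scatter) in this assay and is the first step between compounds that differ in one place. It shows that what sits on this double-bonded chain carbon matters in this assay, and that growth inhibition does not depend on keeping the (4-methylbenzyl)sulfanyl group, since (4-methylphenyl)sulfonyl on the otherwise unchanged core of compound 1 gives the lower number. Nothing in the data at hand accounts for the size of this step.

The swap alters both the sulfur group and the link to the ring, and with no (4-methylbenzyl)sulfonyl or (4-methylphenyl)sulfanyl group among the compounds shown, these two parts cannot be separated. Going by these compounds, whether the step holds on other cores, or with an amine or a carboxylic acid on the aromatic ring of this group, stays open.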